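Dimethylamino to bromo: expected step to compound 4

The compounds below may be only part of what the source reports. "The series", "measured", "known", "first", "only" and "open" are said of these compounds alone.

In a functional assay on A549 cells (Homo sapiens) for cytotoxicity, read by MTT assay, with a stated time of 24 h (a lower number here means a stronger inhibitor, a higher number a weaker inhibitor), compound 1 `COc1ccc(/C=C(\C#N)C(=O)N/N=C(\C)c2c(O)c3ccc(O)cc3oc2=O)cc1` gives 8150 nM, compound 2 `C/C(=N\NC(=O)/C(C#N)=C/c1ccc(Br)cc1)c1c(O)c2ccc(O)cc2oc1=O` gives 11400 nM and compound 3 `C/C(=N\NC(=O)/C(C#N)=C/c1ccc(N(C)C)cc1)c1c(O)c2ccc(O)cc2oc1=O` gives 4310 nM. Compound 3 stands clear of compound 2 only, with a 2.6-fold lower number from compound 2 to compound 3 (0.42 log units; beyond the scatter). It is not separated from compound 1, with a 1.9-fold lower number from compound 1 to compound 3 (0.28 log units; within the scatter), and the remaining pair shows a 1.4-fold higher number from compound 1 to compound 2 (0.15 log units; within the scatter).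

Compound 4 `C/C(=N\NC(=O)/C(C#N)=C/c1cccc(Br)c1)c1c(O)c2ccc(O)cc2oc1=O` is not yet measured. Its difference from compound 3 is 3-bromophenyl in place of 4-(dimethylamino)phenyl on a double-bonded chain carbon bound to a double-bonded chain carbon.

Among the compounds with values here, the most relevant measured change is the one between compound 2 and compound 3, read in reverse, since compound 2 also carries a bromo group. Within the data shown here, no measured compound has the 3-bromophenyl group, so the data do not show what its placement contributes. A modest rise in this assay is therefore expected, of about the size seen for that pair. The estimated change is a 2.3-fold higher number from compound 3 to compound 4 (0.37 log units; beyond the scatter). Compound 4 is estimated at 10000 nM, with an expected range of 4500 nM to 22000 nM.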

Compound 4, half-maximal inhibitory concentration: 22200 nM
Compound 4: middle estimate off by 2.2-fold (0.35 log units), on the low side, and the stated range ends below it.
By their numbers in this assay, from the lowest: compounds 3, 1, 2 and 4 (each within the scatter of the next, the first and the last beyond it).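

In this assay, the group on the double-bonded chain carbon now gives its widest spread in the series, with a 5.2-fold higher number from compound 3 to compound 4 (0.71 log units; beyond the scatter) as the largest step. Moving the bromo group does not separate the two bromo compounds, at a 1.9-fold higher number from compound 2 to compound 4 (0.29 log units; within the scatter) in this read-out, so no effect of its placement can be claimed. 3-Bromophenyl does stand clear of 4-methoxyphenyl, at a 2.7-fold higher number from compound 1 to compound 4 (0.44 log units; beyond the scatter) here, a separation that 4-bromophenyl did not reach against the same group, and nothing at hand speaks to the cause of these steps.

Bromo is the only group shown in the 3-bromophenyl placement, so it remains open whether dimethylamino would keep its low number there. Also open, on these data alone, is how diethylamino, with its longer chains, or a carboxylic acid on the phenyl ring would read.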